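Trading a carbamoyl for a 2-oxopropyl on compound 3

The source may report more compounds than this note shows. Statements on the series, on what has been measured and on what is new or still open speak of the compounds shown alone.

Measured compounds:
Compound 1 `CCCn1c(=O)n(CCOC)c(=O)c2[nH]cnc21` gives 700 nM in a functional assay (trachea) with Cavia porcellus as the target; a higher number here means that more compound is needed for the effect, a lower number that less compound is needed.
Compound 2 `CCCn1c(=O)n(CC(C)=O)c(=O)c2[nH]cnc21` gives 14900 nM in this assay.
Compound 3 `CCCn1c(=O)n(C)c(=O)c2c1ncn2CC(N)=O` gives > 100000 nM in this assay.

Compound 3 stands at the limit of this assay, so for compound 3 only a limit and no number is known (the limit of > 100000 nM in this assay, at which 1 of the 3 values shown sits). Among the compounds with values here, the single measured step, a 21-fold higher number from compound 1 to compound 2 (1.33 log units; beyond the scatter), swaps one group for another on a saturated chain carbon bound to an aromatic nitrogen and was large; it is the only guide to how much such a swap can move the read-out, though it sits on a different nitrogen of the shared core.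

Compound 4 `CCCn1c(=O)n(C)c(=O)c2c1ncn2CCC(C)=O` differs from compound 3 in one place: 2-oxopropyl in place of carbamoyl on a saturated chain carbon bound to an aromatic nitrogen. Since compound 3 offers only a limit, the size of the step to compound 4 is open; the step is expected to be an at least 2.5-fold lower number from compound 3 to compound 4 (0.39 log units; beyond the scatter), in the direction of a lower number, but a result again at the limit would not surprise. Compound 4 is therefore expected to give about 40000 nM, somewhere between 8000 nM and 200000 nM.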

Compound 4, half-maximal effective concentration: 12200 nM
The estimate for compound 4 lay 3.3-fold (0.52 log units) above the measured number; low and high end bracket the measured number.
By their numbers in this assay, from the lowest: compound 1; then compounds 4 and 2 (each within the scatter of the next). At a limit, above all of these: compound 3.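

Within the data shown here, until now, the only measured swap sat on a different nitrogen of the shared core, so nothing showed whether this place could move the read-out at all. In this assay, 2-oxopropyl in place of carbamoyl on a saturated chain carbon bound to an aromatic nitrogen gives an at least 8.1-fold lower number from compound 3 to compound 4 (0.91 log units; beyond the scatter), so this place responds too, and the change turns a result without a number into a measurable one. The step gives only a minimum size, since compound 3 is known as a limit and not as a number: the limit of > 100000 nM in this assay, at which 1 of the 4 values shown sits.

On these data alone, the true size of this step stays unknown, and a single swap cannot show which part of the change matters: the loss of the amide hydrogen or the longer chain. As far as these compounds go, whether an amine or a carboxylic acid on this chain would lower or raise the number also stays open.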